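Working notes: the ethyl to methyl step on compound 1

The source may report more compounds than this note shows. Statements on the series, on what has been measured and on what is new or still open speak of the compounds shown alone.

Measured so far:
compound 1, `CCc1cccc(NC(=O)CN2CCN(c3ccccn3)CC2)c1`: 58%
compound 2, `Cc1cccc(NC(=O)CN2CCN(c3cccc4ccccc34)CC2)c1`: 27.8%

In a functional assay on cells for agonist activity at D(4) dopamine receptor (Homo sapiens), read by TR-FRET and cAMP accumulation, with a stated time of 30 min (a lower number here means a smaller maximal response, a higher number a larger maximal response), compound 1 gives 58%, the higher of the two numbers. For the measured compounds named here, compound 2 gives 27.8%, a gap beyond the scatter, but the two structures differ in more than one place and no single step joins them. Compound 3, `Cc1cccc(NC(=O)CN2CCN(c3ccccn3)CC2)c1`, is not yet measured. It differs from compound 1 as follows: hydrogen in place of methyl on a saturated chain carbon bound to an aromatic carbon. With no single-point comparison at hand, a small step is expected, if any downward, a number 8 percentage points lower from compound 1 to compound 3 (within the scatter). For compound 3 the estimated maximal response is 50%, with a range from 30% to 70%.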

Compound 3, largest response reached (Emax), in percent of the reference or control that the assay uses: 64.2%
Beside the measured number, compound 3's estimate is 14.2 percentage points below it; low and high end bracket the measured number.
By their numbers in this assay, from the lowest: compound 2; then compounds 1 and 3 (each within the scatter of the next).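

For the compounds shown here, the step from ethyl to methyl reads a number 6.2 percentage points higher from compound 1 to compound 3 (within the scatter) in this assay and is the first comparison that changes one place only. On a saturated chain carbon bound to an aromatic carbon, hydrogen in place of methyl therefore does not move the maximal response beyond the scatter, so the full ethyl group is not required for this response. No available measurement accounts for this result.

Left open is how the response behaves with a longer chain such as propyl, or with a methoxy group or a chlorine atom in place of the ethyl. Also open, on these data alone, is whether the same tolerance holds when the rest of the core of compound 1 is changed.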